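Methyl added to the amine chain of a pyridopyrimidine series

The source may report more compounds than this note shows. Statements on the series, on what has been measured and on what is new or still open speak of the compounds shown alone.

Three compounds share one core and were tested in a functional assay on HT-29 cells (Homo sapiens) for cytotoxicity, read by neutral red uptake, with a stated time of 72 h; a higher number here means a weaker inhibitor, a lower number a stronger inhibitor. Compound 1 `CCCCCCCNc1nc(SCC)nc2ncccc12` gives 19900 nM. Compound 2 `CCCCCCCNc1nc(SC(C)C)nc2ncccc12` gives 24400 nM. The two differ by methyl in place of hydrogen on a saturated chain carbon bound to a saturated chain carbon and a sulfur, and the step is a 1.2-fold higher number from compound 1 to compound 2 (0.09 log units; within the scatter). Compound 3 `CCCCCNc1nc(SCCCC)nc2ncccc12` gives 12600 nM; compound 3 and compound 1 are built from the same atoms joined differently, and the difference between the two cores is not broken down here. All three numbers lie within the scatter of one another.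

Compound 4 `CCCCCCNc1nc(SCCCC)nc2ncccc12` has not been measured. It differs from compound 3 by methyl in place of hydrogen on a saturated chain carbon, five bonds along the chain from a nitrogen on an aromatic ring. This is the same kind of change as that from compound 1 to compound 2, not the same one: there the methyl entered on a saturated chain carbon bound to a saturated chain carbon and a sulfur, here it enters on a saturated chain carbon five bonds along the chain from a nitrogen on an aromatic ring. Within the data shown here, the single earlier step of this kind stayed within the scatter, so a step of a 1.1-fold lower number from compound 3 to compound 4 (0.06 log units; within the scatter) is expected from compound 3 to compound 4 in this assay, resting on compound 3 at 12600 nM. Compound 4 is estimated at 11000 nM, between 5000 nM and 25000 nM.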

Compound 4, half-maximal inhibitory concentration: 2800 nM
For compound 4 the middle estimate is 3.9-fold (0.59 log units) above the measured one, outside the stated range (below it).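

In this assay, the methyl on the amine chain, five bonds along the chain from a nitrogen on an aromatic ring, gave a 4.5-fold lower number from compound 3 to compound 4 (0.65 log units; beyond the scatter). Among these compounds, the earlier methyl step, which entered on the sulfur-bound chain, did not predict the size of this one, so the change did not carry over as a single step from one core to the other: the same change on two cores in this assay, a 1.2-fold higher number (0.09 log units; within the scatter) from compound 1 to compound 2 and a 4.5-fold lower number (0.65 log units; beyond the scatter) from compound 3 to compound 4, 5.5-fold (0.74 log units) apart, beyond the scatter of two such steps This shows that, in this series, a methyl in place of hydrogen cannot be given one expected effect; with only one pair at each place, it does not show whether the gap comes from where the methyl sits or from the rest of the structure.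

The compounds shown leave open whether a longer chain on the amine would lower the number further, or whether an amine or a carboxylic acid at the chain end would keep the gain. They also leave open whether the same step on the amine chain would recur with a different sulfur-bound chain.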